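Shifting the Methyl Around the Phenyl Ring of Compound 3

A few compounds are considered here, and "the series" means these few. Any claim that something is new, unique, unknown or untested is made for them only; others in the source may bear on it.

Compound 3 `Cc1ccccc1-c1nnc(CSc2nnc(/N=C/c3ccccc3O)s2)o1` stands second highest of the three numbers measured in a functional assay on SMMC-7721 cells (Homo sapiens) for inhibition, read by CCK-8 assay (a higher number here means a weaker inhibitor, a lower number a stronger inhibitor), where compound 3 gives 15500 nM. Its nearest neighbour is compound 1 `Oc1ccccc1/C=N/c1nnc(SCc2nnc(-c3ccccc3Cl)o2)s1`, which in this assay gives 31800 nM; the step of a 2.1-fold lower number from compound 1 to compound 3 (0.31 log units; beyond the scatter) is modest. The furthest is compound 2 `Oc1ccccc1/C=N/c1nnc(SCc2nnc(-c3ccc(Cl)cc3)o2)s1`, which in this assay gives 2840 nM; the step of a 5.5-fold higher number from compound 2 to compound 3 (0.74 log units; beyond the scatter) is modest as well.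

Compound 4 `Cc1cccc(-c2nnc(CSc3nnc(/N=C/c4ccccc4O)s3)o2)c1` differs from compound 3 in one place: 3-methylphenyl in place of 2-methylphenyl on an aromatic carbon.

Among the measured compounds shown here, only one measured step concerns moving a substituent around this phenyl ring, namely an 11-fold lower number from compound 1 to compound 2 (1.05 log units; beyond the scatter), and it was large. That step went from 2-chlorophenyl to 4-chlorophenyl; no 3-substituted phenyl of any kind has been measured, so the 3-methylphenyl of compound 4 cannot be placed directly from the data. Since moving a group away from the 2-chlorophenyl arrangement gave a clearly lower number, the step expected for compound 4 is a 2.6-fold lower number from compound 3 to compound 4 (0.41 log units; beyond the scatter), a smaller step than the chloro case. Compound 4 is therefore estimated at 6000 nM in this assay, within a range from 2000 nM to 18000 nM.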

Compound 4, half-maximal inhibitory concentration: 4550 nM
For compound 4 the middle estimate is 1.3-fold (0.12 log units) above the measured one, within the range that was stated.
By their numbers in this assay, from the lowest: compounds 2 and 4 (each within the scatter of the next); then compound 3; then compound 1.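

In this assay, going from 2-methylphenyl to 3-methylphenyl gives a clear shift (a 3.4-fold lower number from compound 3 to compound 4 (0.53 log units; beyond the scatter)), so the earlier chloro step is no longer a lone case: in both pairs, the compound with the group in the 2-substituted phenyl arrangement carries the higher number, although the two pairs differ in which position the group moves to. The new compound also links the methyl and chloro compounds, since it cannot be separated from the 4-chlorophenyl compound (a 1.6-fold higher number from compound 2 to compound 4 (0.20 log units; within the scatter)) but stands well apart from the 2-chlorophenyl compound (a 7.0-fold lower number from compound 1 to compound 4 (0.84 log units; beyond the scatter)), which suggests that among these four compounds the placement on the phenyl ring counts for at least as much as the choice between methyl and chloro. Nothing available here speaks to what lies behind these steps.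

From the compounds shown here alone, whether 4-methylphenyl would match compound 4, and whether 3-chlorophenyl would follow the methyl case, remains open. So does what a methoxy group, an amine or a carboxylic acid on this phenyl ring would do to the number in this assay.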